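The source may hold more compounds than are shown below. What is called first, only, known or untested is meant among the compounds shown, and "the series" means these compounds.

Compound 3 `CC1(C)Oc2ccc(C#N)cc2[C@@H](OC2=CC(=O)CC2)[C@]1(C)O` gives 20 nM in a functional assay for inhibition, with Sus scrofa as the target (on this read-out lower numbers stand for stronger inhibition and higher numbers for weaker inhibition), the lowest of the two numbers in the series. Compound 1 `CC1(C)Oc2ccc(C#N)cc2[C@@H](Oc2ccccn2)[C@]1(C)O` gives 6000 nM in this assay, and the gap is a 300-fold lower number from compound 1 to compound 3 (2.48 log units; beyond the scatter). Within the data shown here, compound 2 `CC1(C)Oc2ccc(C#N)cc2[C@@H](On2ccccc2=O)[C@]1(C)O` reaches only a limit of the assay, > 100000 nM in this assay, which is the one value sitting at the limit of > 100000 nM in this assay, at which 1 of the 3 values shown sits. Compound 4 `CC1(C)Oc2ccc(C#N)cc2[C@@H](n2nc(N)ccc2=O)[C@]1(C)O` has not been measured in this assay. It differs from compound 3 by a group of 8 heavy atoms (4 carbon, 3 nitrogen, 1 oxygen; one six-membered aromatic ring with 2 hetero atoms) in place of a group of 7 heavy atoms (5 carbon, 2 oxygen; one five-membered non-aromatic ring of carbon only), on a saturated ring carbon.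

Among the measured compounds shown here, two measured steps bear on this change, each putting the five-membered non-aromatic ring of carbon only in place of a six-membered aromatic ring with one hetero atom, on an oxygen on a saturated carbon: a 300-fold lower number from compound 1 to compound 3 (2.48 log units; beyond the scatter) and an at least 5000-fold lower number from compound 2 to compound 3 (3.69 log units; beyond the scatter), both large. Compound 4 runs the other way, taking the five-membered non-aromatic ring out for a six-membered aromatic ring with two hetero atoms, now on a saturated ring carbon rather than on an oxygen, a placement without a measured parallel here. A large rise in the number is therefore expected, with its size uncertain. The step is expected to be a 100-fold higher number from compound 3 to compound 4 (2.00 log units; beyond the scatter). Compound 4 is estimated at 2000 nM in this assay, within a range from 200 nM to 30000 nM.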

Compound 4, half-maximal inhibitory concentration: 40000 nM
Estimate against measurement, compound 4: 20-fold (1.30 log units) below, outside the stated range (above it).
By their numbers in this assay, from the lowest: compound 3; then compound 1; then compound 4. At a limit, above all of these: compound 2.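

The group entering on the saturated ring carbon in this assay gives a 2000-fold higher number from compound 3 to compound 4 (3.30 log units; beyond the scatter) in a single change, which places compound 4 with the aromatic-ring compounds and far from the 3-oxocyclopent-1-en-1-yl compound. Against the pyridin-2-yl group the same entering group gives only a 6.7-fold higher number from compound 1 to compound 4 (0.82 log units; beyond the scatter) and is modest next to the step from compound 3; at this position all three compounds carrying a six-membered aromatic ring stand above compound 3, with none going against this among the compounds shown. Compound 2 has only a limit of the assay, so an at least 2.5-fold lower number from compound 2 to compound 4 (0.39 log units; beyond the scatter) is a bound and not a measured size, and the order of these two rests on that limit: the limit of > 100000 nM in this assay, at which 1 of the 4 values shown sits.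

The compounds shown do not separate the effect of the ring from that of its attachment, as no one group appears both on the oxygen and on the saturated ring carbon. Also open, going by these compounds, is how the amino group on the entering ring contributes, and whether a carboxylic acid or a longer chain in its place would move the number.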